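A few compounds are considered here, and "the series" means these few. Any claim that something is new, unique, unknown or untested is made for them only; others in the source may bear on it.

Compound 1 `COc1cc(/C=C/C(=O)O)ccc1OC(=O)c1nc(C)c(C)nc1C` and compound 3 `Cc1nc(C)c(C(=O)Oc2ccc(/C=C/C(=O)O)cc2)nc1C` are built on one core, while compound 2 `CCOC(=O)/C=C/c1cc(OC)ccc1OC(=O)c1nc(C)c(C)nc1C` and compound 4 `CCOC(=O)/C=C/c1ccccc1OC(=O)c1nc(C)c(C)nc1C` are built on another; how the two cores differ is not broken down here. In a functional assay on EA.hy 926 cells (Homo sapiens) for cytotoxicity, read by MTT assay, with stated times of 24 h and 12 h, tested at 12.5 uM (a higher number here means a stronger effect of the compound at the concentration tested, a lower number a weaker effect), compound 1 gives 38.7%, compound 3 gives 34.2% and compound 2 gives 15.9%. Compound 2 has the lowest of the three numbers, and its gaps to compound 3 and to compound 1 both lie beyond the scatter. The change from compound 1 to compound 3 is hydrogen in place of methoxy on an aromatic carbon and made a step of a number 4.5 percentage points lower from compound 1 to compound 3 (within the scatter). The change from compound 2 to compound 4 is hydrogen in place of methoxy on an aromatic carbon, the same kind of change, though the place differs: in compound 1 the methoxy sits ortho to a large group and meta to a 2-carboxyethenyl group, while in compound 2 it sits meta to a 2-(ethoxycarbonyl)ethenyl group and para to a large group. Because the earlier step was a number 4.5 percentage points lower from compound 1 to compound 3 (within the scatter), the expected step is also small, a number 1.9 percentage points lower from compound 2 to compound 4 (within the scatter). Among the measured compounds shown here, only one earlier example of this change is known, and it sits on a different core at a different place, so the expectation is loose. Compound 4 is therefore estimated to give 14% in this assay, with a range from 4% to 28%.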

Compound 4, a percentage reported as activity, at one concentration (the size of the read-out at that concentration, not a potency): 9.6%
Compound 4: the middle estimate sits 4.4 percentage points above what was measured; measured number inside the range.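

In this assay the replacement of methoxy by hydrogen on the core of compound 2 made a step of a number 6.3 percentage points lower from compound 2 to compound 4 (within the scatter), and set beside the earlier case the two steps do not differ: the same change on two cores in this assay, a number 4.5 percentage points lower (within the scatter) from compound 1 to compound 3 and a number 6.3 percentage points lower (within the scatter) from compound 2 to compound 4, 1.8 percentage points apart, within the scatter of two such steps. Within this series the change therefore carries from one core to the other as a small step on both, and the earlier step gave a fair guide to the size of the new one. Among the compounds shown here, this does not establish a rule, since it rests on only two pairs, a single assay and a single concentration; the methoxy also sits at a different place on each core, and steps within the scatter cannot show that removing the group moves the read-out at all, or that the same would hold on any third core.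

The compounds shown leave open whether another group in the place of the methoxy, such as a hydroxyl, a chlorine or an amine, would give a step beyond the scatter where methoxy and hydrogen do not. They also leave open whether the small step would persist on a core bearing a longer chain in the ester in place of the 2-(ethoxycarbonyl)ethenyl group.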